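Anilide in Place of Propylamide on a Hydroxypyrimidinone Core

The compounds below may be only part of what the source reports. "The series", "measured", "known", "first", "only" and "open" are said of these compounds alone.

The two measured compounds are compound 1, `CC(=O)Nc1ccc2c(=O)n(O)c(=O)[nH]c2c1`, and compound 2, `CCCNC(=O)c1nc(-c2cccs2)[nH]c(=O)c1O`. In an assay on isolated protein for inhibition of Flap endonuclease 1 (Homo sapiens) (a lower number here means a stronger inhibitor, a higher number a weaker inhibitor), compound 1 gives 2100 nM, and in this assay compound 2 gives 4200 nM. Among the measured compounds shown here, these are the only two numbers available, and the gap between them lies within the scatter of repeated measurements, so neither compound can be called the stronger inhibitor on this evidence.

Compound 3, `O=C(Nc1ccc(F)cc1)c1nc(-c2cccs2)[nH]c(=O)c1O`, shares the core of compound 2 and differs from it in one place: 4-fluorophenyl in place of propyl on an amide-type nitrogen. For the measured compounds named here, no pair of measured compounds separated by a single change exists here, so the size of this step cannot be read from data; it has to be judged from the change alone, which replaces a short chain by an aromatic ring on the amide-type nitrogen.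

In this assay the expected step is a 2.8-fold lower number from compound 2 to compound 3 (0.45 log units; beyond the scatter), a moderate decrease. The estimate for compound 3 in this assay is 1500 nM, within a range from 400 nM to 6000 nM.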

Compound 3, half-maximal inhibitory concentration: 10500 nM
Estimate against measurement, compound 3: 7.0-fold (0.85 log units) below; measured number outside the range, above it.
By their numbers in this assay, from the lowest: compounds 1 and 2 (each within the scatter of the next); then compound 3.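

In this assay the step at this amide-type nitrogen can now be read, and it is a loss: 4-fluorophenyl in place of propyl gives a 2.5-fold higher number from compound 2 to compound 3 (0.40 log units; beyond the scatter) and thus a weaker inhibitor. The position is therefore not indifferent to what it carries, and on this shared core an aromatic ring bearing fluorine does not improve on a short chain. Neither group has hydrogen-bond donors, hydrogen-bond acceptors or a net charge, so the change is one of carbon framework and fluorine, but no measurement available explains why the number rises.

Since the ring and the fluorine enter together, the compounds shown cannot separate their contributions, and plain phenyl would be needed to tell whether the ring alone goes with the higher number. Going by these compounds, it also remains open how a benzyl group, which sets the ring further out on a carbon link, or a longer chain such as butyl, or a propyl chain ending in an amine or a carboxylic acid, would behave at this nitrogen.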